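The compounds below may be only part of what the source reports. "The series", "measured", "known", "first", "only" and "open" are said of these compounds alone.

Compound 1 `C=CC(=O)Nc1cccc(-c2nc3ccccc3s2)c1`: in an ADME assay on BJ cells (Homo sapiens) for inhibition, with a stated time of 72 h (a lower number here means that less compound is needed, a higher number that more compound is needed for the effect), compound 1 gives > 25000 nM, which is a limit of the assay.
Compound 2 `C=C(C)C(=O)Nc1cccc(-c2nc3ccccc3s2)c1`: compound 2 gives > 25000 nM, also a limit.
Compound 3 `O=C(Nc1cccc(-c2nc3ccccc3s2)c1)c1cnccc1Cl`: compound 3 gives > 25000 nM, again a limit.

Compound 2 therefore stands only at a limit, and the two further values shown are limits as well (the limit of > 25000 nM in this assay, at which 3 of the 3 values shown sit). Compound 4 `O=C(Nc1cccc(-c2nc3ccccc3s2)c1)c1cccnc1Cl` differs from compound 2 by 2-chloropyridin-3-yl in place of 1-methylethenyl on a carbonyl carbon. For the measured compounds named here, the steps that bear on this change are a step that the two limits leave unreadable from compound 2 to compound 3, a step that the two limits leave unreadable from compound 1 to compound 3 and a step that the two limits leave unreadable from compound 1 to compound 2; none of them can be read, because every value sits at the limit of > 25000 nM in this assay, at which 3 of the 3 values shown sit. No step beyond the scatter is therefore expected in either direction. Compound 4 is expected to give about 40000 nM, with a range from 10000 nM to 200000 nM, most likely again as a limit. That expectation means a step that the limit leaves unreadable from compound 2 to compound 4.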

Compound 4, half-maximal effective concentration: > 25000 nM
Compound 4 was reported as a limit (the forecaster's own chance of this, stated with the estimate: 85%); the middle value is on the limit's open side.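

For the compounds shown here, no step between compound 4 and compound 1, compound 2 or compound 3 can be read, because all of these values are limits: the limit of > 25000 nM in this assay, at which 4 of the 4 values shown sit. As far as these compounds go, whether any of these groups on the carbonyl carbon changes the result in this assay stays open.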